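Adding Bromo to a Weak Compound

A few compounds are considered here, and "the series" means these few. Any claim that something is new, unique, unknown or untested is made for them only; others in the source may bear on it.

compound 1 `CC(C)n1c(/C=C2/C(=O)Nc3ccc(Br)cc32)nc2ccccc21`: 12400 nM
compound 2 `CCn1c(/C=C2/C(=O)Nc3ccccc32)nc2ccccc21`: > 50000 nM
compound 3 `CC(C)n1c(/C=C2/C(=O)Nc3ccccc32)nc2ccccc21`: 33500 nM

In a functional assay on HGC cells (Homo sapiens) for cytotoxicity, read by MTT assay, with a stated time of 48 h (a higher number here means a weaker inhibitor, a lower number a stronger inhibitor), compound 2 reads > 50000 nM, which is a limit of the assay and not a number. Compound 2 sits at the limit of > 50000 nM in this assay, at which 1 of the 3 values shown sits.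

Compound 4 `CCn1c(/C=C2/C(=O)Nc3ccc(Br)cc32)nc2ccccc21` is compound 2 with one change: bromo in place of hydrogen on an aromatic carbon. The closest evidence is the same change run in reverse, with hydrogen in place of bromo: a 2.7-fold higher number from compound 1 to compound 3 (0.43 log units; beyond the scatter). That modest step lies beyond the scatter. The other measured step concerns a methyl in place of hydrogen on the chain, not the bromo: an at least 1.4-fold lower number from compound 2 to compound 3 (0.17 log units; that floor lies within the scatter). It suggests that compound 2 may not lie far from its limit, though that floor is within the scatter.

A modest move to a lower number, meaning a stronger inhibitor, is therefore expected in this assay. The expected size is an at least 2.0-fold lower number from compound 2 to compound 4 (0.31 log units; beyond the scatter). The starting point is only a limit and a single bromo step has been measured, so the range stays wide. For compound 4 the estimated value is 24000 nM, with an expected range of 13000 nM to 50000 nM.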

Compound 4, half-maximal inhibitory concentration: > 50000 nM
Compound 4: no number, only a limit; the forecaster's own chance of this, stated with the estimate: 15%; at least 2.0-fold (0.31 log units) between middle value and limit.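

In this assay, the result for compound 4 is a limit, and so is the result for compound 2, so the step between them cannot be read and the effect of bromo on this core stays unmeasured. A step can be read on the bromo-bearing core, where hydrogen in place of methyl on the chain carbon bound to the aromatic nitrogen gives an at least 4.0-fold higher number from compound 1 to compound 4 (0.60 log units; beyond the scatter). Shortening the chain therefore costs a clear amount with bromo present, and the comparison with the bromo-free pair remains unsettled: the same change on two cores in this assay, an at least 1.4-fold lower number (0.17 log units; that floor lies within the scatter) from compound 2 to compound 3 and an at least 4.0-fold lower number (0.60 log units; beyond the scatter) from compound 4 to compound 1; the limit leaves it open whether they differ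

On these data alone, how far compound 2 and compound 4 lie past the limit remains unknown: the limit of > 50000 nM in this assay, at which 2 of the 4 values shown sit. Also open is how a longer chain on the aromatic nitrogen, or an amine on the aromatic carbon that carries the bromo, would read.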